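The source may report more compounds than this note shows. Statements on the series, on what has been measured and on what is new or still open speak of the compounds shown alone.

Measured compounds in a functional assay on MCF7 cells (Homo sapiens) for cytotoxicity, read by MTT assay, with a stated time of 72 h; on this read-out higher numbers stand for weaker inhibition and lower numbers for stronger inhibition:
compound 1, `Cc1c(C(=O)Nc2ccc(Oc3ccnc4[nH]ccc34)c(F)c2)nnn1-c1ccc(F)cc1`, gives 170 nM
compound 2, `Cc1c(C(=O)Nc2ccc(Oc3ccnc4[nH]ccc34)c(F)c2)nnn1-c1ccc(F)c(F)c1`, gives 820 nM
compound 3, `Cc1c(C(=O)Nc2ccc(Oc3ccnc4[nH]ccc34)cc2)nnn1-c1ccccc1`, gives 320 nM

From compound 1 to compound 2 the change is fluoro in place of hydrogen on an aromatic carbon; it gave a 4.8-fold higher number from compound 1 to compound 2 (0.68 log units; beyond the scatter). Compound 3 and compound 1 sit within the scatter of each other, and the difference between their two cores is not broken down here.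

Compound 4, `Cc1c(C(=O)Nc2ccc(Oc3ccnc4[nH]ccc34)cc2)nnn1-c1ccccc1F`, has not been measured; it differs from compound 3 by fluoro in place of hydrogen on an aromatic carbon. The place is not the same as in the earlier pair: there the fluoro entered ortho to a fluoro group and meta to a large group, here ortho to a large group, so this is the same kind of change, not the same change.

For compound 4 the expected step is a 2.0-fold higher number from compound 3 to compound 4 (0.31 log units; beyond the scatter), resting on the earlier step of a 4.8-fold higher number from compound 1 to compound 2 (0.68 log units; beyond the scatter), with the altered surroundings of the place making the size uncertain. Compound 4 is estimated at 650 nM in this assay, with a range from 250 nM to 1700 nM.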

Compound 4, half-maximal inhibitory concentration: 280 nM
Compound 4: the middle estimate sits 2.3-fold (0.37 log units) above what was measured; the range from low to high includes it.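

Fluoro in place of hydrogen on an aromatic carbon does not carry over as a step of fixed size between the two cores in this assay: the same change on two cores in this assay, a 4.8-fold higher number (0.68 log units; beyond the scatter) from compound 1 to compound 2 and a 1.1-fold lower number (0.06 log units; within the scatter) from compound 3 to compound 4, 5.5-fold (0.74 log units) apart, beyond the scatter of two such steps

On the core of compound 3, phenyl to 2-fluorophenyl gives a 1.1-fold lower number from compound 3 to compound 4 (0.06 log units; within the scatter). The two pairs differ both in core and in the place of the fluoro, so the compounds shown do not separate these two, and they do not show which of them accounts for the gap.

Open, on these data alone, is what the same place of the fluoro would give on the core of compound 1. Also open, as far as these compounds go, is how the phenyl ring of compound 3 answers to groups other than fluoro, such as chloro, methyl, methoxy or an amine.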